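Para substituent exchange on the oxygen-linked aryl ring

A few compounds are considered here, and "the series" means these few. Any claim that something is new, unique, unknown or untested is made for them only; others in the source may bear on it.

The two measured compounds share a core bearing a cyclohexylbutyl carbamate and differ only in the group on the ring oxygen. Compound 1 `C[C@H]1[C@H](NC(=O)OCCCCC2CCCCC2)C(=O)N1OCCCCc1ccccc1` carries 4-phenylbutyl there, and in an assay on HEK293 cells for inhibition of N-acylethanolamine-hydrolyzing acid amidase (Homo sapiens), read by fluorescence, with stated times of 10 min and 50 min (a lower number here means a stronger inhibitor, a higher number a weaker inhibitor), compound 1 gives 1240 nM. Compound 2 `C[C@H]1[C@H](NC(=O)OCCCCC2CCCCC2)C(=O)N1Oc1ccc(C(F)(F)F)cc1` carries 4-(trifluoromethyl)phenyl instead, and in this assay compound 2 gives 31 nM; the exchange from compound 1 to compound 2 gave a 40-fold lower number from compound 1 to compound 2 (1.60 log units; beyond the scatter). Among the compounds with values here, compound 2 thus stands at the lower of the two numbers measured so far, with compound 1 the only comparator.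

Compound 3 `COC(=O)c1ccc(ON2C(=O)[C@@H](NC(=O)OCCCCC3CCCCC3)[C@@H]2C)cc1` is the next member: methoxycarbonyl in place of trifluoromethyl on an aromatic carbon. Within the data shown here, the one measured step concerns the whole group on the oxygen, alkyl chain against aryl ring, and does not speak to exchanging one substituent for another on an aryl ring that stays in place. Among the measured compounds shown here, no measured pair bears directly on the change. The aryl ring kept by compound 3 is the feature that separates compound 2 from compound 1, so a step of about the same size as that one is not expected; the expected change from compound 2 to compound 3 is a 1.8-fold higher number from compound 2 to compound 3 (0.25 log units; within the scatter), within the scatter or a modest loss. Compound 3 is therefore estimated at 55 nM in this assay, with a range of 15 nM to 220 nM.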

Compound 3, half-maximal inhibitory concentration: 17 nM
For compound 3 the middle estimate is 3.2-fold (0.51 log units) above the measured one, within the range that was stated.
By their numbers in this assay, from the lowest: compounds 3 and 2 (each within the scatter of the next); then compound 1.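

Working notes on the aryl position: in this assay the place para to a large group accepts methoxycarbonyl for trifluoromethyl with a 1.8-fold lower number from compound 2 to compound 3 (0.26 log units; within the scatter) on the readout, so two groups that differ in their counted hydrogen-bond acceptors and in the double bond of the carbonyl are not separated at this place. The large separation between an aryl ring and the 4-phenylbutyl chain on the oxygen now appears with a second aryl substituent, as a 73-fold lower number from compound 1 to compound 3 (1.86 log units; beyond the scatter) shows, and so it does not rest on trifluoromethyl alone. No supporting data are available to explain either step, whether the one within the scatter or the large one.

The compounds shown leave open how a carboxylic acid, an amine or a nitrile would read at this same place on the ring, and whether an unsubstituted phenyl ring would stay with compound 2 and compound 3 or fall toward compound 1. They also leave open whether the aryl result holds when the cyclohexylbutyl carbamate, unchanged throughout, gives way to a shorter or longer chain.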